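This account rests on a few compounds, and the source may have more. Where it says the series, first, only, none or still open, it means among the compounds named here.

Measured so far in an ADME assay on the whole organism (Mus musculus, strain BALB/c) for pharmacokinetics, read by LC-MS, with a stated time of 24 h, at a dose of 1 mg/kg by the intravenous route; on this read-out higher numbers stand for fast clearance and lower numbers for slow clearance:
Compound 1 `O=S(=O)(Nc1ncccn1)c1ccc2c(c1)OCC[C@@H]2c1ccc(C(F)(F)F)cc1-c1ccc(F)nc1`: 2.6 mL/min/kg
Compound 2 `O=S(=O)(Nc1nccs1)c1ccc2c(c1)OCC[C@@H]2c1ccc(C(F)(F)F)cc1-n1ccnn1`: 37 mL/min/kg

Of these two numbers, compound 2 has the higher, at 37 mL/min/kg. Compound 1 lies lower, at 2.6 mL/min/kg, and this gap is beyond the usual scatter of repeated measurements.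

The next compound, compound 3 `O=S(=O)(Nc1nccs1)c1ccc2c(c1)OCC[C@@H]2c1ccc(C(F)(F)F)cc1-c1ccc(F)nc1`, is still unmeasured. It differs from compound 2 in one place: 6-fluoropyridin-3-yl in place of 1H-1,2,3-triazol-1-yl on an aromatic carbon. Here, 6-fluoropyridin-3-yl takes the place of 1H-1,2,3-triazol-1-yl on an aromatic carbon, ortho to a large group and meta to a trifluoromethyl group.

Within the data shown here, no measured pair shows this change alone, so any forecast rests on thin evidence. The incoming group is also carried by compound 1, at 2.6 mL/min/kg, but compound 1 and compound 2 differ in more than this group. A fall beyond the scatter in this assay is therefore expected, though probably not across the whole gap. Compound 3 is estimated at 9 mL/min/kg, with an expected range of 3 mL/min/kg to 27 mL/min/kg. This estimate means an expected 4.1-fold lower number from compound 2 to compound 3 (0.61 log units; beyond the scatter).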

Compound 3, clearance in the Mus musculus assay: 14 mL/min/kg
Compound 3: the middle estimate sits 1.6-fold (0.19 log units) below what was measured; the measured number falls inside the stated range.
By their numbers in the Mus musculus assay, from the lowest: compound 1; then compound 3; then compound 2.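

In the Mus musculus assay, with the 1,3-thiazol-2-yl sulfonamide held constant, 6-fluoropyridin-3-yl in place of 1H-1,2,3-triazol-1-yl gives a 2.6-fold lower number from compound 2 to compound 3 (0.42 log units; beyond the scatter), so the group on this aromatic carbon affects clearance on its own. With 6-fluoropyridin-3-yl held constant, 1,3-thiazol-2-yl in place of pyrimidin-2-yl on the sulfonamide nitrogen gives a 5.4-fold higher number from compound 1 to compound 3 (0.73 log units; beyond the scatter), showing that this second place also matters independently. In a physicochemical assay for solubility (a higher number here means a more soluble compound, a lower number a less soluble compound), compound 2 gives 171000 nM and compound 3 gives 21000 nM. The slower clearance from the change to 6-fluoropyridin-3-yl comes with a drop in solubility in the physicochemical assay: the measured solubility of compound 2, 171000 nM, and of compound 3, 21000 nM, an 8.1-fold lower number (0.91 log units; beyond the scatter)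

Among these compounds, only two groups on this aromatic carbon can be compared here, so it remains open whether lower clearance and lower solubility must always go together at this position. A small amine or a carboxylic acid on the same carbon would test that link, and a triazole paired with the pyrimidin-2-yl sulfonamide would show whether the two places act independently of each other.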